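Removing the distal phenyl from compound 1

The source may report more compounds than this note shows. Statements on the series, on what has been measured and on what is new or still open speak of the compounds shown alone.

Compound 1 `NC(C/C=C(\c1ccc(-c2ccccc2)cc1)c1ccc(F)cc1F)C(=O)O` sits at the edge of a functional assay for inhibition of sodium- and chloride-dependent glycine transporter 1 (Rattus norvegicus), with a stated time of 30 min, in the presence of a further agent that is not named here; a lower number here means a stronger inhibitor, a higher number a weaker inhibitor: in this assay compound 1 gives > 10000 nM, which is a limit rather than a number. Its geometric isomer, compound 2 `NC(C/C=C(/c1ccc(-c2ccccc2)cc1)c1ccc(F)cc1F)C(=O)O`, gives 3400 nM in this assay. For the measured compounds named here, the only step measured within the set, an at least 2.9-fold lower number from compound 1 to compound 2 (0.46 log units; beyond the scatter), concerns the drawn configuration of the double bond, and the fact that one of compounds 1 and 2 is drawn with a defined configuration and the other without, at the place where they differ is all that separates the pair. Compound 3 `CC(C)c1ccc(/C(=C\CC(N)C(=O)O)c2ccc(C#N)cc2)cc1`, carrying a different pair of aryl groups, gives > 10000 nM in this assay, again a limit. Because of the limit of > 10000 nM in this assay, at which 2 of the 3 values shown sit, compound 1 stands at the upper edge of what this assay reports, with no number of its own to build on.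

Compound 4 `NC(C/C=C(\c1ccccc1)c1ccc(F)cc1F)C(=O)O` differs from compound 1 by hydrogen in place of phenyl on an aromatic carbon, para to a large group. Going by the values given here, no measured step touches this place; the one measured step, an at least 2.9-fold lower number from compound 1 to compound 2 (0.46 log units; beyond the scatter), lies at the double bond and does not bear on the aromatic ring. Starting from a limit, the loss of the phenyl is not expected to bring the number down into the measurable range; the change is expected to amount to a step that the limit leaves unreadable from compound 1 to compound 4, no improvement beyond the scatter. Compound 4 is therefore estimated at 20000 nM, with a range of 8000 nM to 60000 nM, most likely reported again only as a limit.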

Compound 4, half-maximal inhibitory concentration: 9500 nM
Compound 4: middle estimate off by 2.1-fold (0.32 log units), on the high side; low and high end bracket the measured number.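

With hydrogen in place of phenyl, compound 4 gives 9500 nM in this assay, so this position now carries a measured number on the core of compound 1, and the phenyl is not required for a value inside the measurable range. Compound 1 gives > 10000 nM, which is a limit and not a number. The change therefore reads only as a floor, an at least 1.0-fold lower number from compound 1 to compound 4 (0.02 log units; that floor lies within the scatter), which shows no gain beyond the scatter and leaves the true size of the step unreadable.

Open, on these data alone, is whether a group other than hydrogen or phenyl at this position, such as a methoxy group or a chlorine atom, moves the number. Also open, as far as these compounds go, is whether the step at the double bond, an at least 2.9-fold lower number from compound 1 to compound 2 (0.46 log units; beyond the scatter), carries over to compounds with hydrogen at this position.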